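The source may hold more compounds than are shown below. What is called first, only, known or untested is meant among the compounds shown, and "the series" means these compounds.

Measured compounds:
compound 1 `CN(C)CCCNc1nc(-c2ccc(NC(=O)Nc3ccc(Cl)cc3Cl)cc2)nc2c(Cl)c(Cl)sc12` — 2560 nM
compound 2 `Cc1ccc(NC(=O)Nc2ccc(-c3nc(NCCCN(C)C)c4sc(Cl)c(Cl)c4n3)cc2)cc1` — 3700 nM
compound 3 `CCN(CC)CCCNc1nc(-c2ccc(NC(=O)Nc3ccc(Cl)cc3Cl)cc2)nc2c(Cl)c(Cl)sc12` — 5720 nM

All three were tested in a functional assay on MKN-45 cells (Homo sapiens) for cytotoxicity, read by MTT assay, with a stated time of 72 h; a higher number here means a weaker inhibitor, a lower number a stronger inhibitor. Compound 1 gives 2560 nM, and compound 2 differs from it by 4-methylphenyl in place of 2,4-dichlorophenyl on an amide-type nitrogen, a change that brought a 1.4-fold higher number from compound 1 to compound 2 (0.16 log units; within the scatter). Compound 3 differs from compound 1 by diethylamino in place of dimethylamino on a saturated chain carbon, three bonds along the chain from a nitrogen on an aromatic ring, with a 2.2-fold higher number from compound 1 to compound 3 (0.35 log units; beyond the scatter); compound 3 gives 5720 nM.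

Compound 4 `CCN(CC)CCCNc1nc(-c2ccc(NC(=O)Nc3ccc(C)cc3)cc2)nc2c(Cl)c(Cl)sc12` has not yet been measured in this assay. It differs from compound 3 by 4-methylphenyl in place of 2,4-dichlorophenyl on an amide-type nitrogen, the same change already seen from compound 1 to compound 2, on a core that carries the diethylamino rather than the dimethylamino group.

Because compound 1 to compound 2 gave a 1.4-fold higher number from compound 1 to compound 2 (0.16 log units; within the scatter), the expected step for compound 4 is a 1.4-fold higher number from compound 3 to compound 4 (0.15 log units; within the scatter). Compound 4 is therefore estimated at 8000 nM, with a likely range from 4000 nM to 16000 nM.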

Compound 4, half-maximal inhibitory concentration: 3320 nM
The estimate for compound 4 lay 2.4-fold (0.38 log units) above the measured number, and the stated range ends above it.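

In this assay, 4-methylphenyl in place of 2,4-dichlorophenyl on an amide-type nitrogen gave a 1.7-fold lower number from compound 3 to compound 4 (0.24 log units; within the scatter), and the two readings of this change do not differ: the same change on two cores in this assay, a 1.4-fold higher number (0.16 log units; within the scatter) from compound 1 to compound 2 and a 1.7-fold lower number (0.24 log units; within the scatter) from compound 3 to compound 4, 2.5-fold (0.40 log units) apart, within the scatter of two such steps. Diethylamino in place of dimethylamino gave a 1.1-fold lower number from compound 2 to compound 4 (0.05 log units; within the scatter), and this change likewise reads the same on both cores: the same change on two cores in this assay, a 2.2-fold higher number (0.35 log units; beyond the scatter) from compound 1 to compound 3 and a 1.1-fold lower number (0.05 log units; within the scatter) from compound 2 to compound 4, 2.5-fold (0.40 log units) apart, within the scatter of two such steps. Neither change is thus shown to depend on the core, but with only two readings of each, this does not show that either step carries over reliably, and the direction of each remains unsettled.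

The compounds shown leave open how other groups on that nitrogen, such as a 4-methoxyphenyl or a pyridine ring, would behave. Other amines at the chain end, such as pyrrolidine or morpholine, also remain open.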